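Removing the Isopropylamino Group from Compound 1

The source may hold more compounds than are shown below. What is called first, only, known or untested is meant among the compounds shown, and "the series" means these compounds.

In a functional assay on the whole organism with Mus musculus as the target, in the rotarod test (a higher number here means that more compound is needed for the effect, a lower number that less compound is needed), compound 1 (`CC(C)NCC(=O)NCC(=O)N(C)c1ccc(Cl)cc1C(=O)c1ccccc1Cl`) gives 13 mg/kg as the higher of the two numbers available. Compound 2 (`CN(C(=O)CNC(=O)CN)c1ccc([N+](=O)[O-])cc1C(=O)c1ccccc1`) gives 2.94 mg/kg as the lower number, and the gap between them lies beyond the usual scatter. Compound 3 (`CCC(=O)NCC(=O)N(C)c1ccc(Cl)cc1C(=O)c1ccccc1Cl`) has methyl in place of isopropylamino on a saturated chain carbon bound to a carbonyl carbon. Within the data shown here, no measured pair shows this change, so any expectation is loose. Compound 1 at 13 mg/kg and compound 2 at 2.94 mg/kg both keep an amino group, which compound 3 lacks, so a step beyond the scatter towards a higher number is expected in this assay on this thin basis. The estimated move is a 2.3-fold higher number from compound 1 to compound 3 (0.36 log units; beyond the scatter) on these grounds. For compound 3 the estimated value is 30 mg/kg with an expected range from 9 mg/kg to 120 mg/kg as the likely span.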

Compound 3, dose for half-maximal effect: 36 mg/kg
Compound 3: middle estimate off by 1.2-fold (0.08 log units), on the low side; the measured number falls inside the stated range.
By their numbers in this assay, from the lowest: compound 2; then compound 1; then compound 3.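

In this assay, among these compounds, methyl in place of isopropylamino on a saturated chain carbon bound to a carbonyl carbon gives a 2.8-fold higher number from compound 1 to compound 3 (0.44 log units; beyond the scatter), the first measured change confined to one place. The position is therefore not indifferent to this change: with the rest of compound 1 kept, more compound is needed once isopropylamino has gone, although the step is modest. Nothing measured here explains the shift.

The change removes the nitrogen and the hydrogen-bond donor and acceptor counted with it, as well as three heavy atoms overall, so the compounds shown cannot separate the loss of the amine from the loss of chain length. A primary amine or a dimethylamino group at this place, or an isobutyl chain without nitrogen, would address that question.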